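The compounds below may be only part of what the source reports. "The series", "measured", "known", "first", "only" and "open" are said of these compounds alone.

The measured compounds are:
compound 1, `O=C(O)c1cn(-c2ccc(F)cc2)c2nc(N3CCN(C(=O)C4COc5ccccc5O4)CC3)c([N+](=O)[O-])cc2c1=O`; compound 2, `CC(C)(C)NC(=O)C1c2ccccc2CCN1c1nc2c(cc1[N+](=O)[O-])c(=O)c(C(=O)O)cn2-c1ccc(F)cc1`; compound 3, `CC(C)(C)n1cc(C(=O)O)c(=O)c2cc([N+](=O)[O-])c(N3CCN(C(=O)C4COc5ccccc5O4)CC3)nc21`.

In an ADME assay on Vero cells (Chlorocebus sabaeus) for cytotoxicity, read by MTT assay, with a stated time of 72 h (a higher number here means a weaker inhibitor, a lower number a stronger inhibitor), compound 1 gives only a limit, > 54300 nM. In this assay compound 2 gives 112000 nM. In this assay compound 3 gives 116000 nM. Because of the limit of > 54300 nM in this assay, at which 1 of the 3 values shown sits, the step from compound 1 to compound 3 cannot be sized: a step that the limit leaves unreadable from compound 1 to compound 3. That step is tert-butyl in place of 4-fluorophenyl on an aromatic nitrogen. How the core of compound 2 differs from the core of compound 1 is not broken down here. Compound 4, `CC(C)(C)NC(=O)C1c2ccccc2CCN1c1nc2c(cc1[N+](=O)[O-])c(=O)c(C(=O)O)cn2C(C)(C)C`, is not yet measured; it arises from compound 2 by the same change, (tert-butyl in place of 4-fluorophenyl on an aromatic nitrogen). The values of compound 2 and compound 3 lie within the scatter of each other, so a small step is expected for compound 4, a 1.0-fold lower number from compound 2 to compound 4 (0.01 log units; within the scatter). Compound 4 is estimated at 110000 nM in this assay.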

Compound 4, half-maximal inhibitory concentration: 120000 nM
The estimate for compound 4 lay 1.1-fold (0.04 log units) below the measured number; the range from low to high includes it.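

In this assay, tert-butyl in place of 4-fluorophenyl on the aromatic nitrogen gives a 1.1-fold higher number from compound 2 to compound 4 (0.03 log units; within the scatter) and so cannot be told from scatter on the core of compound 2. The value of compound 1 is a limit and not a number. This leaves no readable comparison between the two cores, and nothing shows that the change behaves alike on both, because the step from compound 1 to compound 3 cannot be read: the limit of > 54300 nM in this assay, at which 1 of the 4 values shown sits.

Still open, as far as these compounds go, is how other groups on that aromatic nitrogen, such as ethyl or cyclopropyl, would read in this assay. Also open, from the compounds shown here alone, is what a methyl ester in place of the carboxy group would do.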